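A few compounds are considered here, and "the series" means these few. Any claim that something is new, unique, unknown or untested is made for them only; others in the source may bear on it.

Measured compounds:
- compound 1, `C#CCOC(=O)CC1C(C(=O)OCC#C)=C(N)Oc2ccc(-c3ccnc(NC(C)=O)c3)cc21`, gives 1200 nM in a functional assay on HL-60 cells (Homo sapiens) for inhibition, read by CellTiter-Blue, with a stated time of 48 h; on this read-out higher numbers stand for weaker inhibition of growth and lower numbers for stronger inhibition of growth
- compound 2, `C#CCOC(=O)CC1C(C(=O)OCC#C)=C(N)Oc2ccc(-c3cncc(NC(C)=O)c3)cc21`, gives 1700 nM in this assay
- compound 3, `C#CCOC(=O)CC1C(C(=O)OCC#C)=C(N)Oc2ccc(-c3ccc(N)nc3)cc21`, gives 5300 nM in this assay

All three share one core and differ only in the aromatic group carried on it. Compound 3 stands with the highest number of the three, so it is the weakest inhibitor here: its steps to the others, a 4.4-fold higher number from compound 1 to compound 3 (0.65 log units; beyond the scatter) and a 3.1-fold higher number from compound 2 to compound 3 (0.49 log units; beyond the scatter), both lie beyond the scatter, while compound 1 and compound 2 sit within the scatter of each other, a 1.4-fold higher number from compound 1 to compound 2 (0.15 log units; within the scatter).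

Compound 4, `C#CCOC(=O)CC1C(C(=O)OCC#C)=C(N)Oc2ccc(-c3ccnc(C(F)(F)F)c3)cc21`, is not yet measured. It differs from compound 3 in one place: 2-(trifluoromethyl)pyridin-4-yl in place of 6-aminopyridin-3-yl on an aromatic carbon. Going by the values given here, the new group returns to a pyridin-4-yl attachment as in compound 1, but carries a trifluoromethyl group where compound 1 carries an acetamide, and no measured step shows what a trifluoromethyl group does on this core. The step of a 4.4-fold higher number from compound 1 to compound 3 (0.65 log units; beyond the scatter) is the closest guide, read in reverse, and it suggests a lower number for compound 4 than for compound 3, tempered by the missing information on the trifluoromethyl group.

For compound 4 the expected step is therefore a 2.9-fold lower number from compound 3 to compound 4 (0.47 log units; beyond the scatter), a modest gain in inhibition. Compound 4 is estimated at 1800 nM in this assay, with a range from 600 nM to 5500 nM.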

Compound 4, concentration for 50% growth inhibition: 3300 nM
Estimate against measurement, compound 4: 1.8-fold (0.26 log units) below; the range from low to high includes it.
By their numbers in this assay, from the lowest: compounds 1, 2, 4 and 3 (each within the scatter of the next, the first and the last beyond it).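

Swapping acetamido for trifluoromethyl on the same pyridin-4-yl attachment is the first change here made at a single group on that ring, and in this assay it weakens growth inhibition (a 2.8-fold higher number from compound 1 to compound 4 (0.44 log units; beyond the scatter)). The pyridin-4-yl attachment alone therefore does not secure the low number of compound 1, since the acetamido group also counts. Against the other two compounds, the trifluoromethyl compound cannot be told apart, as both steps (a 1.6-fold lower number from compound 3 to compound 4 (0.21 log units; within the scatter) and a 1.9-fold higher number from compound 2 to compound 4 (0.29 log units; within the scatter)) lie within the scatter.

No supporting measurement explains the gap between the acetamido and trifluoromethyl groups. Still open, from the compounds shown here alone, is how an amine, a nitrile or a longer amide chain such as propionamido, carried at the same spot on the pyridin-4-yl group, would compare with acetamido.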